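Hydrazone series: trihydroxyphenyl for chlorophenyl on two cores

The source may report more compounds than this note shows. Statements on the series, on what has been measured and on what is new or still open speak of the compounds shown alone.

Compound 3 `O=C(CCCc1nc2ccccc2c(=O)[nH]1)N/N=C/c1ccc(Cl)cc1` gives 67000000 nM in a functional assay on cells (Erythrocyte, Homo sapiens) for inhibition, read by spectrophotometry and hemolysis, with a stated time of 10 min; a lower number here means a stronger inhibitor, a higher number a weaker inhibitor. Compound 1 `O=C(CCCc1nc2ccccc2c(=O)[nH]1)N/N=C/c1cc(O)c(O)c(O)c1` gives 183000000 nM in this assay. One change separates them, (3,4,5-trihydroxyphenyl in place of 4-chlorophenyl on a carbon with a double bond to nitrogen), and it made a step of a 2.7-fold higher number from compound 3 to compound 1 (0.44 log units; beyond the scatter). Compound 2 `O=C(CCc1nc2ccccc2c(=O)[nH]1)N/N=C/c1ccc(Cl)cc1` gives 84000000 nM in this assay; its value and that of compound 3 lie within the scatter of each other, so no order between them is read. The cores of compound 2 and compound 3 differ, and the difference between the two cores is not broken down here. Compound 4 `O=C(CCc1nc2ccccc2c(=O)[nH]1)N/N=C/c1cc(O)c(O)c(O)c1` is not yet measured in this assay. Among the compounds with values here, it differs from compound 2 by 3,4,5-trihydroxyphenyl in place of 4-chlorophenyl on a carbon with a double bond to nitrogen, the same change as the one made from compound 3 to compound 1, at the same place in the printed sense. Within the data shown here, with only one example of this change measured, the expectation rests on that single step. The step from compound 2 to compound 4 is expected to be a 2.6-fold higher number from compound 2 to compound 4 (0.42 log units; beyond the scatter), of about the size seen in a 2.7-fold higher number from compound 3 to compound 1 (0.44 log units; beyond the scatter). Compound 4 is estimated at 220000000 nM, between 110000000 nM and 450000000 nM.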

Compound 4, half-maximal inhibitory concentration in the Erythrocyte assay: 203000000 nM
Beside the measured number, compound 4's estimate is 1.1-fold (0.03 log units) above it; measured number inside the range.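

In the Erythrocyte assay compound 2 gives 84000000 nM and compound 4 gives 203000000 nM. In the Erythrocyte assay the change from 4-chlorophenyl to 3,4,5-trihydroxyphenyl gives a 2.4-fold higher number from compound 2 to compound 4 (0.38 log units; beyond the scatter), so the move towards a weaker inhibitor seen on the core of compound 3 recurs on the core of compound 2, and the two steps do not differ in size: the same change on two cores in the Erythrocyte assay, a 2.7-fold higher number (0.44 log units; beyond the scatter) from compound 3 to compound 1 and a 2.4-fold higher number (0.38 log units; beyond the scatter) from compound 2 to compound 4, 1.1-fold (0.05 log units) apart, within the scatter of two such steps

This is one pair on each of two cores, so it supports carrying the change between these two cores and gives no rule for any other core. Nor does the direction hold across assays. In a physicochemical assay, read by spectrophotometry, with a stated time of 6 min (a higher number here means a weaker inhibitor, a lower number a stronger inhibitor), compound 2 gives 185000000 nM and compound 4 gives 35000000 nM. In the physicochemical assay the same change gives a 5.3-fold lower number from compound 2 to compound 4 (0.72 log units; beyond the scatter), the opposite direction, and that step is shown on one core only.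

The compounds shown leave open whether all three hydroxyl groups are needed for these steps, since a phenyl carrying a single hydroxyl does not appear among them. They also leave open how the change behaves with a carboxylic acid or an amine on the phenyl ring, or with a longer chain in the core.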